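Changing the Sulfonyl Aryl Group of Compound 1

The source may hold more compounds than are shown below. What is called first, only, known or untested is meant among the compounds shown, and "the series" means these compounds.

Compound 1 `CC1CCN(c2c(S(=O)(=O)c3cc(F)cc(F)c3)cnc3cc(Cl)ccc23)CC1` gives 94% in an assay on isolated protein for displacement of a labelled ligand from metabotropic glutamate receptor 5 (Homo sapiens), with a stated time of 60 min, tested at 1 uM (a lower number here means less inhibition, a higher number more inhibition at the concentration tested (going by the name of the read-out)), nominally the top of the three measured numbers, though compound 3 `Cc1ccc2ncc(S(=O)(=O)c3ccc(F)c(Cl)c3)c(N3CCC(C)CC3)c2c1` with 93% sits within the usual scatter of it, so the two cannot be ordered. Going by the values given here, compound 2 `CC1CCN(c2c(S(=O)(=O)c3cc(F)cc(F)c3)cnc3cc(F)ccc23)CC1` gives 77%, and the one measured single change, a number 17 percentage points lower from compound 1 to compound 2 (beyond the scatter), is fluoro in place of chloro on an aromatic carbon. Compound 4 `COc1ccc(S(=O)(=O)c2cnc3cc(Cl)ccc3c2N2CCC(C)CC2)cc1Cl` differs from compound 1 elsewhere: 3-chloro-4-methoxyphenyl in place of 3,5-difluorophenyl on a sulfonyl sulfur. Among the compounds with values here, no measured step touches the group on the sulfonyl sulfur, so only the values of compound 1 and compound 3, which lie within the usual scatter of each other, hint that the number may stay level when this group is changed. The estimate for compound 4 is therefore 85%, between 65% and 98%, a step of a number 9 percentage points lower from compound 1 to compound 4 (within the scatter) expected to stay near the scatter.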

Compound 4, a percentage reported as inhibition, at one concentration (the size of the read-out at that concentration, not a potency): 93%
The estimate for compound 4 lay 8 percentage points below the measured number; the measured number falls inside the stated range.
By their numbers in this assay, from the lowest: compound 2; then compounds 3, 4 and 1 (each within the scatter of the next).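

The group on the sulfonyl sulfur now has a measured single change of its own: 3-chloro-4-methoxyphenyl in place of 3,5-difluorophenyl in this assay gives a number 1 percentage points lower from compound 1 to compound 4 (within the scatter), so the two compounds cannot be ordered. This aryl swap, which brings in one hydrogen-bond acceptor, therefore leaves no readable difference in this read-out. No measurement shown here offers an explanation for this result.

As far as these compounds go, these percentages come from a single concentration, so any difference in potency between the two compounds remains unknown. From the compounds shown here alone, whether the sulfonyl sulfur can carry a methyl group or a piperidine instead of an aryl ring also remains open.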